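The compounds below may be only part of what the source reports. "The series", "measured", "known", "first", "only" and "open" are said of these compounds alone.

Measured so far:
compound 1, `CCCCCCCCCCCCCCCCO[C@H]1O[C@H](CO)[C@@H](O)[C@H](O)[C@H]1NC(C)=O`: 13 uM
compound 2, `CCCCCCCC/C=C\CCCCCCCCO[C@H]1O[C@H](CO)[C@@H](O)[C@H](O)[C@H]1NC(C)=O`: 1.3 uM
compound 3, `CCCCC(=O)N[C@H]1[C@@H](OCCc2ccccc2)O[C@H](COCC(CO)(CO)CO)[C@@H](O)[C@@H]1O`: a limit only

All three were tested in a functional assay on C6 cells (Rattus norvegicus), read by thymidine incorporation; a lower number here means a stronger inhibitor, a higher number a weaker inhibitor. Compound 1 gives 13 uM. Compound 2 gives 1.3 uM, the lowest of the two plain numbers shown. For compound 3 the assay reports no number, only the limit > 50 uM. Among the compounds with values here, the one step between compounds that differ in a single place is a 10-fold lower number from compound 1 to compound 2 (1.00 log units; beyond the scatter), a change in the chain and not in the shared core. Within the data shown here, the only other point of evidence is the limit of > 50 uM in this assay, at which 1 of the 3 values shown sits, and it too concerns the chain, not the core.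

Compound 4, `CCCCCCCC/C=C\CCCCCCCCO[C@H]1O[C@H](CO)[C@@H](O)[C@H](OS(=O)(=O)O)[C@H]1NC(C)=O`, differs from compound 2 by sulfo in place of hydrogen on an oxygen on a saturated carbon, a change on the shared core, cut one bond further out read as hydroxy to sulfooxy. Among the measured compounds shown here, no measured step touches that part of compound 2, so the data give no direction for this change. Compound 4 is therefore expected to stay near compound 2, with the step of a 1.5-fold higher number from compound 2 to compound 4 (0.19 log units; within the scatter) expected to sit within the scatter. Compound 4 is estimated at 2 uM, in a wide range from 0.3 uM to 15 uM.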

Compound 4, concentration for 50% inhibition: 12.3 uM
Compound 4: middle estimate off by 6.2-fold (0.79 log units), on the low side, and the stated range covers the measured number.
By their numbers in this assay, from the lowest: compound 2; then compounds 4 and 1 (each within the scatter of the next). At a limit, above all of these: compound 3.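

In this assay, the change from hydroxy to sulfooxy gives a 9.5-fold higher number from compound 2 to compound 4 (0.98 log units; beyond the scatter), the first sign that this oxygen on the shared core affects the number and that the chain is not the only part that does. Within the data shown here, the step runs opposite in direction to the only chain step, a 10-fold lower number from compound 1 to compound 2 (1.00 log units; beyond the scatter), and is of a similar order, so one change on the core can take back a gain of that size made in the chain. The change does not abolish inhibition, since compound 4 still gives a plain number, 12.3 uM, rather than a limit, although nothing shown explains why the number rises at this position.

The compounds shown leave open whether the rise belongs to the sulfooxy group itself or would also follow from another group on this oxygen, such as a phosphate, an acetyl or a methyl ether. They also leave open whether sulfooxy would give a step of the same size on the saturated chain of compound 1, or at the other hydroxy groups of the shared core.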